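Chlorophenyl position swap in a hydrazone series: cytotoxicity notes

The source may report more compounds than this note shows. Statements on the series, on what has been measured and on what is new or still open speak of the compounds shown alone.

Measured so far:
compound 1, `COc1ccc(OC)c(/C=N/NC(=O)c2ccc(-c3cccc(Cl)c3)nc2C)c1` — 188 ug/mL
compound 2, `COc1cc(/C=N/NC(=O)c2ccc(-c3cccc(Cl)c3)nc2C)cc(OC)c1OC` — 495 ug/mL
compound 3, `COc1cc(/C=N/NC(=O)c2ccc(-c3ccc(Cl)cc3)nc2C)cc(OC)c1OC` — 41.1 ug/mL

Three compounds have numbers in an ADME assay on WI-38 cells (Homo sapiens) for cytotoxicity, read by colorimetric assay and crystal violet staining, with a stated time of 24 h; a lower number here means a stronger inhibitor, a higher number a weaker inhibitor. Compound 2 and compound 3 share a core and differ in one place only: 4-chlorophenyl in place of 3-chlorophenyl on an aromatic carbon. That single change made a 12-fold lower number from compound 2 to compound 3 (1.08 log units; beyond the scatter), the largest movement in the set. Compound 1 carries the same 3-chlorophenyl group as compound 2 but a different core; the difference between the two cores is not broken down here. In this assay compound 1 gives 188 ug/mL, which stands second highest of the three numbers, with compound 2 higher and compound 3 lower, both beyond the scatter.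

Compound 4, `COc1ccc(OC)c(/C=N/NC(=O)c2ccc(-c3ccc(Cl)cc3)nc2C)c1`, has not been measured. It differs from compound 1 by 4-chlorophenyl in place of 3-chlorophenyl on an aromatic carbon, and the place described for this change is word for word the same as for the pair compound 2 to compound 3, so it is the same change on the other core.

For compound 4 in this assay the expected step from compound 1 is a 7.5-fold lower number from compound 1 to compound 4 (0.88 log units; beyond the scatter), set beside a 12-fold lower number from compound 2 to compound 3 (1.08 log units; beyond the scatter) and resting on that one pair alone. Because a 12-fold lower number from compound 2 to compound 3 (1.08 log units; beyond the scatter) comes from a single pair on a different core, the step is expected to carry over only in part, and the range is kept wide. Compound 4 is estimated at 25 ug/mL, between 8 ug/mL and 80 ug/mL.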

Compound 4, half-maximal inhibitory concentration: 500 ug/mL
For compound 4 the middle estimate is 20-fold (1.30 log units) below the measured one; the whole stated range lies below it.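

In this assay the swap to 4-chlorophenyl in place of 3-chlorophenyl on the core of compound 1 gives a 2.7-fold higher number from compound 1 to compound 4 (0.42 log units; beyond the scatter), a step in the opposite direction to the one seen on the other core. Across these two pairs, the size and direction of the step depend on the core, so the change cannot be carried from one core to the other as a fixed increment: the same change on two cores in this assay, a 12-fold lower number (1.08 log units; beyond the scatter) from compound 2 to compound 3 and a 2.7-fold higher number (0.42 log units; beyond the scatter) from compound 1 to compound 4, 32-fold (1.51 log units) apart, beyond the scatter of two such steps

The two pairs do not show which part of the difference between the cores is responsible, and with a single pair on each core, they give no rule for how the change would behave on any further core.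

Still open, on these data alone, is whether the opposite directions are tied to the methoxy groups that set the two cores apart, which cores bearing a hydroxyl group or an amine in place of those methoxy groups could help to test. Also open, as far as these compounds go, is whether the same reversal appears when the chlorine on the phenyl ring gives way to fluorine or a trifluoromethyl group.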